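Compound 3, the mirror image of compound 1

The source may hold more compounds than are shown below. What is called first, only, known or untested is meant among the compounds shown, and "the series" means these compounds.

Among the measured compounds shown here, in an ADME assay on MDCK cells (Canis lupus familiaris) for permeability, read by LC-MS, with a stated time of 90 min, tested at 2 uM (on this read-out higher numbers stand for higher permeability and lower numbers for lower permeability), compound 1 `Cc1cc(C)c(CN2CCc3c(Cl)cc([C@H](CO)[C@H]4CCOC4)c(Cl)c3C2=O)c(=O)[nH]1` gives 2.9 10^-6 cm/s as its only number. Compound 2 `COC(c1cc(Cl)c2c(c1Cl)C(=O)N(Cc1c(C)cc(C)[nH]c1=O)CC2)C1CCOC1` stands higher, with 17.1 10^-6 cm/s; 18.7 10^-6 cm/s; 15.4 10^-6 cm/s; 18.4 10^-6 cm/s (4 entries) across its repeat entries. Compound 3 `Cc1cc(C)c(CN2CCc3c(Cl)cc([C@@H](CO)[C@@H]4CCOC4)c(Cl)c3C2=O)c(=O)[nH]1` is the mirror image of compound 1, with the two compounds have the same atoms and bonds and differ only in configuration as drawn: 2 of 2 stereo elements differ (all stereocentres are inverted: mirror images); a stereocentre at a saturated chain carbon is drawn R in compound 1 and S in compound 3; a stereocentre at a saturated ring carbon is drawn R in compound 1 and S in compound 3 as the whole change. For the measured compounds named here, no measured pair shows such an inversion. A step beyond the scatter is not expected in this assay in either direction, with compound 1 at 2.9 10^-6 cm/s as the anchor for that expectation. The expected 1.0-fold higher number from compound 1 to compound 3 (0.01 log units; within the scatter) stays within the scatter. Compound 3 is estimated at 3 10^-6 cm/s with a range from 1.5 10^-6 cm/s to 6 10^-6 cm/s on this measure.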

Compound 3, apparent permeability: 3 10^-6 cm/s
Compound 3: middle estimate and measured number agree at the digits printed, within the range that was stated.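

In this assay, inverting both stereocentres gives a 1.0-fold higher number from compound 1 to compound 3 (0.01 log units; within the scatter), the first measured inversion in this series. The read-out therefore does not separate the two mirror images, and the comparison concerns configuration alone: the fact that compounds 1 and 3 differ only in the configuration as drawn

Among the compounds shown here, it remains open whether inverting only the stereocentre at the saturated chain carbon or only the one at the saturated ring carbon would give a similar result. On these data alone, it is also open how an amine or a carboxylic acid in place of the hydroxyl group would read in this assay.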